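The source may hold more compounds than are shown below. What is called first, only, known or untested is meant among the compounds shown, and "the series" means these compounds.

Compound 1 `CS(=O)(=O)c1ccc(Cc2n[nH]c(=S)n2/N=C/c2c(F)cccc2Cl)cc1` gives 55.3% in a functional assay on HeLa cells (Homo sapiens) for cytotoxicity, read by MTT assay, with a stated time of 48 h, tested at 25 uM; on this read-out lower numbers stand for a weaker effect and higher numbers for a stronger effect at the one concentration tested.
Compound 2 `CSc1ccc(/C=N/n2c(Cc3ccc(S(C)(=O)=O)cc3)n[nH]c2=S)cc1` gives 32.7% in this assay.
Compound 3 `CS(=O)(=O)c1ccc(Cc2n[nH]c(=S)n2/N=C/c2ccc(Cl)cc2)cc1` gives 47.5% in this assay.

Among these three compounds, compound 2 stands lowest in this assay: its number lies beyond the scatter under compound 3 and further still under compound 1. The unmeasured compound 4 `CS(=O)(=O)c1ccc(Cc2n[nH]c(=S)n2/N=C/c2ccccc2F)cc1` is reached from compound 2 by a single change: 2-fluorophenyl in place of 4-(methylsulfanyl)phenyl on a carbon with a double bond to nitrogen. Within the data shown here, the part that leaves is the one that sets compound 2 apart from both measured neighbours, and the part that enters is, like theirs, a phenyl ring carrying a halogen.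

Among the measured compounds shown here, two measured steps bear on this. Going from compound 1 to compound 2 the number fell by a number 22.6 percentage points lower from compound 1 to compound 2 (beyond the scatter), and going from compound 2 to compound 3 it rose by a number 14.8 percentage points higher from compound 2 to compound 3 (beyond the scatter). Both say that exchanging the 4-(methylsulfanyl)phenyl for a halogen-bearing phenyl raises the number in this assay by a modest amount, beyond the scatter. The step from compound 2 to compound 4 is therefore expected to be of similar size and upward, about a number 15.3 percentage points higher from compound 2 to compound 4 (beyond the scatter). For compound 4 the expected value in this assay is 48%, most likely between 35% and 62%.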

Compound 4, a percentage reported as activity, at one concentration (the size of the read-out at that concentration, not a potency): 14%
Beside the measured number, compound 4's estimate is 34 percentage points above it; the whole stated range lies above it.
By their numbers in this assay, from the lowest: compound 4; then compound 2; then compounds 3 and 1 (each within the scatter of the next).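

On a carbon with a double bond to nitrogen, a halogen-bearing phenyl does not by itself lift the number in this assay: 2-fluorophenyl in place of 4-(methylsulfanyl)phenyl gives a number 18.7 percentage points lower from compound 2 to compound 4 (beyond the scatter), the opposite direction to the rise seen with 4-chlorophenyl, which gave a number 14.8 percentage points higher from compound 2 to compound 3 (beyond the scatter). The identity of the halogen-bearing ring therefore matters, as 2-fluorophenyl in place of 4-chlorophenyl gives a number 33.5 percentage points lower from compound 3 to compound 4 (beyond the scatter), and removing only the chloro from the 2-chloro-6-fluorophenyl of compound 1 gives a number 41.3 percentage points lower from compound 1 to compound 4 (beyond the scatter), so among these four compounds the two carrying a chloro on this ring, compound 1 and compound 3, stand above the two without one, compound 2 and compound 4. Nothing measured here gives a reason for this drop.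

Going by these compounds, whether the chloro itself or its combination with the ring's other features carries the higher numbers remains open, and a 2-chlorophenyl or an unsubstituted phenyl at this place would help to separate the two. On these data alone, it is also open how a ring bearing an amine or a carboxylic acid would behave here, and how these compounds would compare at concentrations other than the single one tested.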